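A few compounds are considered here, and "the series" means these few. Any claim that something is new, unique, unknown or untested is made for them only; others in the source may bear on it.

In a functional assay for inhibition, with Homo sapiens as the target (a lower number here means a stronger inhibitor, a higher number a weaker inhibitor), compound 1 (`COc1cc(OC)c(C(=O)/C=C/c2ccc([N+](=O)[O-])cc2)c(OC)c1`) gives 407 nM. Compound 2 (`COc1cc(OC)c(C(=O)/C=C/c2ccccn2)c(OC)c1`) gives 596 nM. For the measured compounds named here, these two numbers lie within the scatter of each other, so compound 1 stands level with the only other measured compound. The account now turns to compound 3 (`COC(=O)c1ccc(/C=C/C(=O)c2c(OC)cc(OC)cc2OC)cc1`), which keeps the core of compound 1 and carries a single change: methoxycarbonyl in place of nitro on an aromatic carbon. Methoxycarbonyl takes the place of nitro on an aromatic carbon, para to a large group. Going by the values given here, no two measured compounds differ in one place only, so the data give no direct measure of this swap in this assay. The one available hint is weak: compound 2, which has no nitro group, gives 596 nM, within the scatter of the value for compound 1. No step beyond the scatter is therefore expected, and neither direction is favoured. The expected outcome is a 1.2-fold higher number from compound 1 to compound 3 (0.09 log units; within the scatter). The estimated value for compound 3 is 500 nM, with an expected range of 200 nM to 1300 nM.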

Compound 3, half-maximal inhibitory concentration: 1930 nM
Compound 3: the middle estimate sits 3.9-fold (0.59 log units) below what was measured; the whole stated range lies below it.
By their numbers in this assay, from the lowest: compounds 1 and 2 (each within the scatter of the next); then compound 3.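

In this assay, replacing nitro with methoxycarbonyl on an aromatic carbon, para to a large group, gives a 4.7-fold higher number from compound 1 to compound 3 (0.68 log units; beyond the scatter). For the compounds shown here, this is the first direct measure of a single change on the shared core, and it shows that this position is not indifferent to what it carries: two groups with the same counts of hydrogen-bond donors and acceptors are clearly told apart, with nitro giving the lower number and so the stronger inhibition. The compounds shown offer no measured property that could account for this step.

Going by these compounds alone, with only this one pair, the data cannot separate the loss of nitro from the arrival of methoxycarbonyl as the source of the step. From the compounds shown here alone, it also remains open how a carboxylic acid, a nitrile or an amine on the same aromatic carbon would read in this assay, and whether the same swap would give a step of similar size on a different core.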